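Bromo to chloro on the 4-bromophenyl compound

The source may report more compounds than this note shows. Statements on the series, on what has been measured and on what is new or still open speak of the compounds shown alone.

Values in a functional assay on MCF7 cells (Homo sapiens) for antiproliferative activity, read by MTT assay, with a stated time of 48 h; a lower number here means a stronger inhibitor, a higher number a weaker inhibitor:
- compound 1 `CC(=O)N1N=C(c2ccc3ccccc3c2)OC1c1ccccc1Br`: 5.49 ug/mL
- compound 2 `CC(=O)N1N=C(c2ccc3ccccc3c2)OC1c1ccc(Br)cc1`: 5.07 ug/mL

Among the compounds with values here, compound 2 stands level with the only other measured compound, within the scatter. Compound 3 `CC(=O)N1N=C(c2ccc3ccccc3c2)OC1c1ccc(Cl)cc1` has chloro in place of bromo on an aromatic carbon, para to a large group: chloro in place of bromo on an aromatic carbon. Within the data shown here, no measured step exchanges one halogen for another. The nearest evidence is the move of the bromine, a 1.1-fold lower number from compound 1 to compound 2 (0.03 log units; within the scatter), which stayed within the scatter. No change beyond the scatter is therefore expected in this assay. The expected step is a 1.0-fold higher number from compound 2 to compound 3 (0.02 log units; within the scatter). For compound 3 the estimated value is 5.3 ug/mL, with an expected range of 2.8 ug/mL to 10 ug/mL.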

Compound 3, half-maximal inhibitory concentration: 2.63 ug/mL
The estimate for compound 3 lay 2.0-fold (0.30 log units) above the measured number; the measured number lies below the stated range.
By their numbers in this assay, from the lowest: compounds 3, 2 and 1 (each within the scatter of the next, the first and the last beyond it).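

In this assay, the exchange of halogen at this position gives a 1.9-fold lower number from compound 2 to compound 3 (0.29 log units; within the scatter), so 4-chlorophenyl and 4-bromophenyl remain level. Within the data shown here, the change from 2-bromophenyl to 4-chlorophenyl gives a 2.1-fold lower number from compound 1 to compound 3 (0.32 log units; beyond the scatter), the only step so far beyond the scatter, and it alters both the halogen and its place on the ring. Nothing available bears on the cause of either step. A 2-chlorophenyl compound would be needed to separate the halogen from its place. As far as these compounds go, whether fluoro, methoxy or an amine at this position would hold the number also stays open.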